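Acetamido for Cyano at a Second Position on the Aryl Ether

This account rests on a few compounds, and the source may have more. Where it says the series, first, only, none or still open, it means among the compounds named here.

Measured compounds:
compound 1, `Cc1cc(COc2ccccc2C#N)nc(-c2ccccn2)n1`, 10000 nM
compound 2, `Cc1cc(COc2cccc(C#N)c2)nc(-c2ccccn2)n1`, 2510 nM
compound 3, `CC(=O)Nc1ccccc1OCc1cc(C)nc(-c2ccccn2)n1`, > 39800 nM

In a functional assay on cells for antagonist activity at Free fatty acid receptor 1 (Homo sapiens), read by TR-FRET and inositol phosphate accumulation, with a stated time of 2 h (a higher number here means a weaker inhibitor, a lower number a stronger inhibitor), compound 1 gives 10000 nM and compound 2 gives 2510 nM. Compound 3 gives only a limit of the assay, > 39800 nM. Compound 1 and compound 2 are built from the same atoms joined differently; how their cores differ is not broken down here, and of the two numbers compound 2 has the lower one.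

Compound 3 differs from compound 1 by acetamido in place of cyano on an aromatic carbon. That step gives an at least 3.9-fold higher number from compound 1 to compound 3 (0.59 log units; beyond the scatter). Its full size is known only as a bound because compound 3 sits at the limit of > 39800 nM in this assay, at which 1 of the 3 values shown sits.

Compound 4, `CC(=O)Nc1cccc(OCc2cc(C)nc(-c3ccccn3)n2)c1`, is not yet measured. It differs from compound 2 by acetamido in place of cyano on an aromatic carbon. Going by the values given here, this is the same kind of change as the one from compound 1 to compound 3, but not the same: there the acetamido stands ortho to a large group, here it stands meta to a large group. Beside the earlier step, the expected step is a 4.8-fold higher number from compound 2 to compound 4 (0.68 log units; beyond the scatter), resting on the weakening seen in an at least 3.9-fold higher number from compound 1 to compound 3 (0.59 log units; beyond the scatter) and on the starting point of compound 2 at 2510 nM. Compound 4 is therefore estimated at 12000 nM in this assay, expected to lie between 4000 nM and 40000 nM.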

Compound 4, half-maximal inhibitory concentration: > 39800 nM
Compound 4 gave a limit, no number; the forecaster's own chance of this, stated with the estimate: 35%; middle value at least 3.3-fold (0.52 log units) from the limit.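

In this assay compound 4 gives only a limit of the assay, > 39800 nM, so the acetamido compound on this second core has no exact number. Acetamido in place of cyano on an aromatic carbon gives an at least 15-fold higher number from compound 2 to compound 4 (1.20 log units; beyond the scatter), and in this series of two pairs the direction of the change carries from one core to the other, with the acetamido compound the weaker inhibitor in both pairs: the same change on two cores in this assay, an at least 3.9-fold higher number (0.59 log units; beyond the scatter) from compound 1 to compound 3 and an at least 15-fold higher number (1.20 log units; beyond the scatter) from compound 2 to compound 4; the limit leaves it open whether they differ. What the pairs do not show is how large the change really is on either core, or whether it is larger on one core than on the other, since neither acetamido compound has an exact value and the two steps are known only as bounds: the limit of > 39800 nM in this assay, at which 2 of the 4 values shown sit.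

Compound 3 and compound 4 stand at the same limit, so the compounds shown leave open which of the two is the weaker inhibitor and whether the place of the acetamido matters at all. They also leave open how a smaller or differently built group, such as an amine, a methoxy group or a carboxylic acid, would compare with cyano at either place on the aryl ether.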